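The compounds below may be only part of what the source reports. "The series", "measured", "known", "first", "only" and "open" are said of these compounds alone.

Compound 2 `Oc1cccc(-c2nc(N3CCCCC3)c3nc[nH]c3n2)c1` is the strongest of the three measured compounds in an assay on cells for displacement of a labelled ligand from adenosine receptor A1 (Homo sapiens), read by scintillation counting and radioligand binding, with a stated time of 60 min (a higher number here means a weaker inhibitor, a lower number a stronger inhibitor), where compound 2 gives 10 nM. Within the data shown here, its closest neighbour is compound 1 `Clc1cccc(-c2nc(N3CCCCC3)c3nc[nH]c3n2)c1`, which gives 50.1 nM in this assay; the only single-point step among the measured compounds, a 5.0-fold lower number from compound 1 to compound 2 (0.70 log units; beyond the scatter), comes from replacing chloro with hydroxy on an aromatic carbon. Furthest away is compound 3 `CN1CCN(c2nc(-c3ccccc3O)nc3c2ncn3C)CC1`, which gives 631 nM in this assay.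

Compound 4 `CN1CCN(c2nc(-c3cccc(O)c3)nc3[nH]cnc23)CC1` shares the core of compound 2 and differs in one place: 4-methylpiperazin-1-yl in place of piperidin-1-yl on an aromatic carbon. Among the measured compounds shown here, no measured step changes this group alone, so the chloro-to-hydroxy step offers no direct guide. Compound 3 does carry 4-methylpiperazin-1-yl, but it also differs from compound 2 at the hydroxyphenyl group and on the fused ring, so its weaker value can only hint that the exchange may cost some binding. A moderate step toward a higher number, beyond the scatter, seems the likeliest outcome. Compound 4 is therefore expected to give 30 nM in this assay, with a range from 8 nM to 120 nM. This estimate corresponds to an expected step of a 3.0-fold higher number from compound 2 to compound 4 (0.48 log units; beyond the scatter).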

Compound 4, inhibition constant: 158 nM
The estimate for compound 4 lay 5.3-fold (0.72 log units) below the measured number, and the stated range ends below it.
By their numbers in this assay, from the lowest: compound 2; then compound 1; then compound 4; then compound 3.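

Among these compounds, the earlier compounds changed only the group on the phenyl ring, so this is the first direct reading of the position on the shared core that carries the saturated ring. In this assay, the exchange of piperidin-1-yl for 4-methylpiperazin-1-yl gives a 16-fold higher number from compound 2 to compound 4 (1.20 log units; beyond the scatter), which shows that binding is clearly sensitive to what sits at this position, even though the two rings are of the same size and differ by little more than a second ring nitrogen and its methyl. Nothing available explains this loss of binding.

The compounds shown cannot say whether the added ring nitrogen or the methyl on it matters more. Piperazin-1-yl without the methyl and morpholin-4-yl at this position would help to separate the two, and this single step says nothing yet about whether the same loss would hold with a different group on the phenyl ring.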